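This account rests on a few compounds, and the source may have more. Where it says the series, first, only, none or still open, it means among the compounds named here.

Compound 1 `CC(=O)OC[C@H]1O[C@H](NS(N)(=O)=O)C=C[C@@H]1OC(C)=O` in a functional assay on A549 cells (Homo sapiens) for cytotoxicity, read by MTT assay, with a stated time of 24 h (on this read-out higher numbers stand for weaker inhibition and lower numbers for stronger inhibition), gives 704000000 nM. Compound 2 `CC(=O)OC[C@H]1O[C@H](NS(=O)(=O)c2ccc(C)cc2)C=C[C@H]1OC(C)=O` carries a 4-methylphenyl on the sulfonyl sulfur; in this assay compound 2 gives > 1000000000 nM, which is a limit of the assay and not a number, so compound 2 stands at the limit of > 1000000000 nM in this assay, at which 1 of the 2 values shown sits. Compound 3 `CC(=O)OC[C@H]1O[C@H](NS(N)(=O)=O)C=C[C@H]1OC(C)=O` arises from compound 2 by amino in place of 4-methylphenyl on a sulfonyl sulfur. Within the data shown here, with compound 2 known only as a limit, no measured step fixes the size of this change. Compound 1, bearing the same amino on the sulfonyl sulfur, gives 704000000 nM. Compound 3 is therefore expected to land near that value, an expected step of an at least 1.4-fold lower number from compound 2 to compound 3 (0.15 log units; that floor lies within the scatter). The estimate for compound 3 is 700000000 nM, range 300000000 nM to 1500000000 nM.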

Compound 3, half-maximal inhibitory concentration: 558000000 nM
The estimate for compound 3 lay 1.3-fold (0.10 log units) above the measured number; low and high end bracket the measured number.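

In this assay, amino in place of 4-methylphenyl on the sulfonyl sulfur now reads as an at least 1.7-fold lower number from compound 2 to compound 3 (0.25 log units; that floor lies within the scatter). The value of compound 2 is a limit of the assay, so this step has only a floor: the limit of > 1000000000 nM in this assay, at which 1 of the 3 values shown sits. The one differing stereocentre shows no change beyond the scatter, with a 1.3-fold lower number from compound 1 to compound 3 (0.10 log units; within the scatter) for a pair of this kind: the fact that compounds 1 and 3 differ only in the configuration as drawn.

From the compounds shown here alone, what a dimethylamino group or a longer alkyl chain on the sulfonyl sulfur would give remains open, as does 4-methylphenyl in the configuration of compound 1.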